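Exchanging the aryl amine for a small acyclic substituent

A few compounds are considered here, and "the series" means these few. Any claim that something is new, unique, unknown or untested is made for them only; others in the source may bear on it.

In a functional assay on PC-3 cells (Homo sapiens) for cytotoxicity, read by MTT assay, with a stated time of 72 h (a lower number here means a stronger inhibitor, a higher number a weaker inhibitor), the compounds of this series differ only in the group on the ring nitrogen of the shared core. Compound 1 `Cc1cc(N2CCNCC2)nc(SCc2nc3ccccc3[nH]2)n1` reaches only a limit of the assay, > 100000 nM; the entry the limit of > 100000 nM in this assay, at which 1 of the 3 values shown sits, marks it as such. Compound 2 `COc1ccccc1Nc1cc(C)nc(SCc2nc3ccccc3[nH]2)n1` gives 70800 nM, and compound 3 `Cc1cc(Nc2ccc(F)cc2)nc(SCc2nc3ccccc3[nH]2)n1` gives 56200 nM. The steps of an at least 1.4-fold lower number from compound 1 to compound 2 (0.14 log units; that floor lies within the scatter) and an at least 1.7-fold lower number from compound 1 to compound 3 (0.25 log units; that floor lies within the scatter) are bounded only from one side by the limit, while a 1.3-fold lower number from compound 2 to compound 3 (0.10 log units; within the scatter) lies within the scatter, so compound 3 sits at the low end of the numbers shown without being separated from compound 2.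

Compound 4 `Cc1cc(NNC(N)=S)nc(SCc2nc3ccccc3[nH]2)n1` is formed from compound 3 by a group of 4 heavy atoms (1 carbon, 2 nitrogen, 1 sulfur; no ring) in place of a group of 7 heavy atoms (6 carbon, 1 fluorine; one six-membered aromatic ring of carbon only), on a nitrogen on an aromatic ring. Within the data shown here, the only step that bears on this change is the one in which the aryl group entered from a small, non-aromatic, donor-bearing substituent, an at least 1.7-fold lower number from compound 1 to compound 3 (0.25 log units; that floor lies within the scatter), and it ran downward. Compound 4 reverses that direction, so a rise in the number is expected, because an at least 1.7-fold lower number from compound 1 to compound 3 (0.25 log units; that floor lies within the scatter) sets the floor for the size. Compound 4 is expected at 90000 nM, within 30000 nM to 300000 nM. This amounts to an expected 1.6-fold higher number from compound 3 to compound 4 (0.20 log units; within the scatter).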

Compound 4, half-maximal inhibitory concentration: > 100000 nM
Compound 4: no number, only a limit (the forecaster's own chance of this, stated with the estimate: 40%); at least 1.1-fold (0.04 log units) between middle value and limit.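

Among these compounds, compound 4 gives only a limit in this assay, so all that can be read for this position is a bound: the limit of > 100000 nM in this assay, at which 2 of the 4 values shown sit. With the aryl group gone from the nitrogen, the readings are an at least 1.7-fold higher number from compound 3 to compound 4 (0.25 log units; that floor lies within the scatter) and an at least 1.4-fold higher number from compound 2 to compound 4 (0.14 log units; that floor lies within the scatter), which adds the first change at this nitrogen that removes the ring, yet both floors leave the acyclic group unseparated from the two aryl amines. The step between the two compounds that carry limits cannot be read.

From the compounds shown here alone, how far compound 4 lies beyond its limit stays open. Also open, going by these compounds, is whether a smaller acyclic group on this nitrogen, such as a methyl or an acetyl, or a benzyl group that keeps a ring, would give a number that can be read.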